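The source may report more compounds than this note shows. Statements on the series, on what has been measured and on what is new or still open speak of the compounds shown alone.

Measured compounds and values in a functional assay on HGC-27 cells (Homo sapiens) for cytotoxicity, read by MTT assay, with a stated time of 72 h; on this read-out lower numbers stand for stronger inhibition and higher numbers for weaker inhibition:

Compound 1 `CCOc1ccccc1Nc1nc(SCc2ccc(C(F)(F)F)cc2)nc2ccccc12` is reported only as the assay limit > 50000 nM.
Compound 2 `Cc1ccccc1Nc1nc(SCc2ccc(C(F)(F)F)cc2)nc2ccccc12` gives 27500 nM.
Compound 3 `O=[N+]([O-])c1cccc(Nc2nc(SCc3ccc(C(F)(F)F)cc3)nc3ccccc23)c1` is reported only as the assay limit > 50000 nM.

Compound 3 therefore stands at the limit, and the limit of > 50000 nM in this assay, at which 2 of the 3 values shown sit, shows that compound 3 is not alone there. The next compound in the series is compound 4 `COc1ccc(Nc2nc(SCc3ccc(C(F)(F)F)cc3)nc3ccccc23)c(OC)c1`. The change from compound 3 to compound 4 is 2,4-dimethoxyphenyl in place of 3-nitrophenyl on a nitrogen on an aromatic ring.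

The measured steps that bear on this are those around the same nitrogen. The step that the two limits leave unreadable from compound 1 to compound 3 is unreadable from the two limits. The step of an at least 1.8-fold higher number from compound 2 to compound 3 (0.25 log units; that floor lies within the scatter) and the step of an at least 1.8-fold lower number from compound 1 to compound 2 (0.25 log units; that floor lies within the scatter) both have a floor within the scatter. Among the compounds with values here, nothing measured so far separates an aryl group on this nitrogen from the limit by a readable margin, so no step beyond the scatter is expected in this assay for compound 4, in either direction; with two of three values already at the limit, a limit is the most likely report. Compound 4 is expected at about 45000 nM (range 15000 nM to 100000 nM), which for the step from compound 3 means an expected at least 1.1-fold lower number from compound 3 to compound 4 (0.04 log units; that floor lies within the scatter).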

Compound 4, half-maximal inhibitory concentration: > 50000 nM
Compound 4 ended at the assay's limit (the forecaster's own chance of this, stated with the estimate: 60%); middle value at least 1.1-fold (0.04 log units) from the limit.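

In this assay compound 4 gives > 50000 nM, which is a limit of the assay. Within the data shown here, the steps joining compound 4 to compound 1 and compound 3 cannot be read, and the one readable step, an at least 1.8-fold higher number from compound 2 to compound 4 (0.25 log units; that floor lies within the scatter), does not establish a separation between 2,4-dimethoxyphenyl and 2-methylphenyl on this nitrogen. Among these compounds, a ring carrying two methoxy groups therefore joins the 2-ethoxyphenyl and 3-nitrophenyl compounds at the limit, leaving compound 2 as the only compound with a number: the limit of > 50000 nM in this assay, at which 3 of the 4 values shown sit.

Going by these compounds, how far compound 1, compound 3 and compound 4 actually lie from compound 2 stays open, so the aryl groups at this position cannot be ranked. Also open, on these data alone, is whether an unsubstituted phenyl, or a morpholinoethyl chain in place of the aryl group, would give a number clearly lower than that of compound 2.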